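Pyridinyloxy in Place of Hydrogen, Judged Against Two Precedents

This account rests on a few compounds, and the source may have more. Where it says the series, first, only, none or still open, it means among the compounds named here.

The measured compounds:
compound 1, `Cc1cc(Br)c(S(C)(=O)=O)cc1C(=O)N=C(N)N`, gives 12 nM in a functional assay for inhibition of sodium/hydrogen exchanger (Oryctolagus cuniculus); on this read-out lower numbers stand for stronger inhibition and higher numbers for weaker inhibition.
compound 2, `Cc1cc(Oc2ccccc2)c(S(C)(=O)=O)cc1C(=O)N=C(N)N`, gives 10 nM in this assay.
compound 3, `Cc1ccc(S(C)(=O)=O)cc1C(=O)N=C(N)N`, gives 150 nM in this assay.

Compound 3 stands at the highest number of the three, and the steps of a 13-fold higher number from compound 1 to compound 3 (1.10 log units; beyond the scatter) and a 15-fold higher number from compound 2 to compound 3 (1.18 log units; beyond the scatter) put it well beyond the scatter from both others. Compound 4, `Cc1cc(Oc2cccnc2)c(S(C)(=O)=O)cc1C(=O)N=C(N)N`, differs from compound 3 by (pyridin-3-yl)oxy in place of hydrogen on an aromatic carbon. The two steps that bear on this change run the other way and are large: a 13-fold higher number from compound 1 to compound 3 (1.10 log units; beyond the scatter) and a 15-fold higher number from compound 2 to compound 3 (1.18 log units; beyond the scatter). The step of a 1.2-fold lower number from compound 1 to compound 2 (0.08 log units; within the scatter) shows the bromo and phenoxy compounds within the scatter of each other, so the phenoxy case is the closer precedent. Compound 4 is therefore expected to move in this assay by a 10-fold lower number from compound 3 to compound 4 (1.00 log units; beyond the scatter) toward a lower number. The estimate for compound 4 is 15 nM, with a range from 6 nM to 40 nM.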

Compound 4, half-maximal inhibitory concentration: 8.8 nM
The estimate for compound 4 lay 1.7-fold (0.23 log units) above the measured number; measured number inside the range.
By their numbers in this assay, from the lowest: compounds 4, 2 and 1 (each within the scatter of the next); then compound 3.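

Placed ortho to a methylsulfonyl group, (pyridin-3-yl)oxy brings a 17-fold lower number from compound 3 to compound 4 (1.23 log units; beyond the scatter) in this assay and so extends the large effect seen with bromo and phenoxy to a third group. Pyridin-3-yl in place of phenyl on the oxygen gives a 1.1-fold lower number from compound 2 to compound 4 (0.06 log units; within the scatter) and the comparison with bromo gives a 1.4-fold lower number from compound 1 to compound 4 (0.13 log units; within the scatter) so all three groups at this position lie within the scatter of one another. Nothing available accounts for this shared level. Still open, going by these compounds, is whether an amine, a carboxylic acid or a longer alkyl chain at this position would reach the same level.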